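Pentyl to hydrogen on selenium: compound 2 to compound 3

The compounds below may be only part of what the source reports. "The series", "measured", "known", "first", "only" and "open" are said of these compounds alone.

Of the compounds shown here, two have numbers so far. Compound 1 `COc1ccc(CNc2nc([SeH])nc3ccccc23)cc1` gives 71600 nM in a functional assay on HT-29 cells (Homo sapiens) for cytotoxicity, read by MTT assay, with a stated time of 72 h; a lower number here means a stronger inhibitor of growth, a higher number a weaker inhibitor of growth. Compound 2 `CCCCC[Se]c1nc(NCc2ccc(SC)cc2)c2ccccc2n1` gives 83600 nM in this assay; this is the highest of the two numbers, and its nearest neighbour is compound 1, whose number is lower by an amount that lies within the scatter of repeated measurements. Both compounds therefore sit in the same weak range, and no order between them can be claimed.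

Compound 3 `CSc1ccc(CNc2nc([SeH])nc3ccccc23)cc1` is not yet measured. It differs from compound 2 in one place: hydrogen in place of pentyl on a selenium. For the measured compounds named here, no pair of measured compounds in this set differs by this change, so there is no measured step to lean on. With both known numbers within the scatter of each other, the working expectation is a step of no more than the scatter in either direction, and the estimated step from compound 2 to compound 3 is a 1.1-fold lower number from compound 2 to compound 3 (0.05 log units; within the scatter). On that basis compound 3 is expected to give about 75000 nM in this assay, with a range from 30000 nM to 190000 nM.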

Compound 3, concentration for 50% growth inhibition: 42900 nM
For compound 3 the middle estimate is 1.7-fold (0.24 log units) above the measured one; the range from low to high includes it.
By their numbers in this assay, from the lowest: compounds 3, 1 and 2 (each within the scatter of the next).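

Two single-place changes can now be read in this assay: hydrogen in place of pentyl on a selenium gives a 1.9-fold lower number from compound 2 to compound 3 (0.29 log units; within the scatter), and methylsulfanyl in place of methoxy on an aromatic carbon gives a 1.7-fold lower number from compound 1 to compound 3 (0.22 log units; within the scatter). For the compounds shown here, both steps lie within the scatter, so the series so far shows no difference that can be claimed between pentyl and hydrogen on this selenium, even though the pentyl chain accounts for 5 heavy atoms, nor between methoxy and methylsulfanyl on the aromatic carbon. No supporting data bear on either step, and neither can be interpreted further.

Open, from the compounds shown here alone, is whether any group on the selenium can move the number beyond the scatter, for example a benzyl group, a longer chain such as decyl, or a short chain ending in a carboxylic acid or an amine. Also open, going by these compounds, is whether the pentyl step would read the same with methoxy in place of methylsulfanyl on the aromatic carbon, and whether sulfur in place of selenium would matter at all.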